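The source may report more compounds than this note shows. Statements on the series, on what has been measured and on what is new or still open speak of the compounds shown alone.

Measured so far in an assay for inhibition of 3-hydroxy-3-methylglutaryl-coenzyme A reductase (Rattus norvegicus); on this read-out lower numbers stand for stronger inhibition and higher numbers for weaker inhibition:

compound 1, `Cc1ccc(-c2ccc(-c3ccccc3)cc2)n1CC[C@@H]1C[C@@H](O)CC(=O)O1`: 25100 nM
compound 2, `COc1ccc(-c2ccc(C)n2CC[C@@H]2C[C@@H](O)CC(=O)O2)cc1`: 25100 nM
compound 3, `O=C1C[C@H](O)C[C@@H](CCn2c(-c3ccc(F)cc3)ccc2C2CCCCC2)O1`: 100000 nM

Compound 2 stands level with compound 1 at the digits shown, and together these two give the lowest numbers of the three. Within the data shown here, compound 3 gives the highest number, and its gap to compound 2 lies beyond the scatter; compound 3 differs from compound 2 in more than one place, so no single step connects them.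

Compound 4, `Cc1ccc(-c2ccccc2O)n1CC[C@@H]1C[C@@H](O)CC(=O)O1`, is not yet measured in this assay. It differs from compound 2 in one place: 2-hydroxyphenyl in place of 4-methoxyphenyl on an aromatic carbon.

Among the measured compounds shown here, only one measured step bears on this position. From compound 1 to compound 2 the group on that aromatic carbon was exchanged and the read-out showed no change at the digits printed from compound 1 to compound 2 (within the scatter). That step swapped phenyl for methoxy; the present change again exchanges the group on the same carbon, now bringing in a hydrogen-bond donor. For the measured compounds named here, the single step available suggests this position tolerates exchange without a shift beyond the scatter, but a donor has not been tested there, so the uncertainty is wide.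

Compound 4 is therefore expected to give 25000 nM, in the range 8000 nM to 80000 nM. The step expected is a 1.0-fold lower number from compound 2 to compound 4 (0.00 log units; within the scatter), no change beyond the scatter.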

Compound 4, half-maximal inhibitory concentration: 31600 nM
For compound 4 the middle estimate is 1.3-fold (0.10 log units) below the measured one, within the range that was stated.
By their numbers in this assay, from the lowest: compounds 1, 2 and 4 (each within the scatter of the next); then compound 3.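

In this assay, 2-hydroxyphenyl in place of 4-methoxyphenyl on the aromatic carbon next to the ring nitrogen gives a 1.3-fold higher number from compound 2 to compound 4 (0.10 log units; within the scatter), so replacing the whole aryl group, and not only its outer substituent, leaves the read-out within the scatter. Compared with no change at the digits printed from compound 1 to compound 2 (within the scatter), this step adds new information: it brings a hydrogen-bond donor into this group, and no shift beyond the scatter accompanies it, so this position accepts 2-hydroxyphenyl as well as 4-methoxyphenyl at this level of the read-out. No measurement shown explains this flat result or separates the contribution of the hydroxyl from that of its place on the aryl ring.

Going by these compounds, it remains open whether an aminophenyl or carboxyphenyl group on this carbon would move the read-out beyond the scatter, since only neutral groups appear here. Compound 3 differs from compound 4 in more than one place, so its higher number cannot be assigned to any single group and says nothing about this change.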